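Phenyl in Place of Imidazolyl on the Amide Carbonyl

The source may report more compounds than this note shows. Statements on the series, on what has been measured and on what is new or still open speak of the compounds shown alone.

Compound 1 `COc1ccc(-c2cnc(NC(=O)c3cnc[nH]3)n2C)cc1` was tested in a toxicity assay on THP-1 cells (Homo sapiens) for inhibition; a higher number here means that more compound is tolerated, a lower number that less compound is tolerated. For compound 1 the result is a limit of the assay, > 100000 nM, not a number. Compound 2 `Cn1c(-c2ccccc2F)cnc1NC(=O)c1ccc(F)cc1` likewise gives only a limit in this assay, > 100000 nM. Compound 3 `COc1ccc(-c2cnc(NC(=O)c3ccc(F)cc3)n2C2CCCC2)cc1` too gives only a limit in this assay, > 100000 nM. All three measured values therefore share one feature: the limit of > 100000 nM in this assay, at which 3 of the 3 values shown sit. Compound 4 `COc1ccc(-c2cnc(NC(=O)c3ccccc3)n2C)cc1` has not yet been measured. It differs from compound 1 in one place, (phenyl in place of 1H-imidazol-5-yl on a carbonyl carbon), that is, phenyl in place of 1H-imidazol-5-yl on a carbonyl carbon. Among the measured compounds shown here, no step between measured compounds is available, so the step is expected to be none beyond the scatter. Compound 4 is estimated at 100000 nM, between 50000 nM and 200000 nM, which means an expected step of a number no higher from compound 1 to compound 4 (the limit leaves the size open).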

Compound 4, half-maximal cytotoxic concentration: > 100000 nM
Compound 4: a limit, no number; the forecaster's own chance of this, stated with the estimate: 80%; the middle value lies on the limit itself.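

The step from compound 1 to compound 4 cannot be read, as both give only a limit in this assay. The compounds shown leave open what half-maximal cytotoxic concentration any of them has, and whether phenyl in place of 1H-imidazol-5-yl alters it.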